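The source may hold more compounds than are shown below. What is called first, only, known or untested is meant among the compounds shown, and "the series" means these compounds.

In an ADME assay on microsomes (Mus musculus) for metabolic stability, tested at 0.8 uM (on this read-out lower numbers stand for a shorter-lived compound and higher numbers for a longer-lived compound), compound 1 `Cc1cccc(C(=O)N[C@@H]2C(=O)Nc3c(c(C)nn3C3CCCC3)[C@@H]2c2ccc(F)cc2)c1` gives 0.5 h, and compound 3 `Cc1ccc([C@H]2c3c(C)nn(-c4ccccc4)c3NC(=O)[C@H]2NC(=O)c2cccc(C)c2)cc1` gives 0.3 h. These two values lie within the usual scatter of each other. Compound 2 `CCN1C(=O)[C@@H](NC(=O)c2cccc(C)c2)[C@@H](c2ccc(F)cc2)c2c(C)nn(C3CC3)c21` reads < 0.1 h, which is a limit of the assay and not a number. Compound 2 therefore stands at the limit of < 0.1 h in this assay, at which 1 of the 3 values shown sits, and its true half-life is not known.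

Compound 4 `CCCn1nc(C)c2c1N(CC)C(=O)[C@@H](NC(=O)c1cccc(C)c1)[C@H]2c1ccc(F)cc1` differs from compound 2 in one place: it has propyl in place of cyclopropyl on an aromatic nitrogen. Among the compounds with values here, no pair of measured compounds shows this swap on its own, so the data offer no direct guide to its size or direction. The expectation is therefore modest, with no change beyond the scatter in this assay and a result that stays close to the limit. The estimated step of a number no lower from compound 2 to compound 4 (the limit leaves the size open) is small for that reason. The assay may well report only a limit again. For compound 4 the estimated half-life is 0.1 h, with an expected range of 0.04 h to 0.25 h.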

Compound 4, half-life: < 0.1 h
Compound 4: no number, only a limit (the forecaster's own chance of this, stated with the estimate: 55%); the middle value lies on the limit itself.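

Compound 2 and compound 4 both give only a limit in this assay, not a number, so no step can be read between them: the limit of < 0.1 h in this assay, at which 2 of the 4 values shown sit.

The compounds shown leave open the true half-life of each and whether propyl in place of cyclopropyl on an aromatic nitrogen changes it at all.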